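Replacing phenoxy with allylamino on a long chain carbonyl

This account rests on a few compounds, and the source may have more. Where it says the series, first, only, none or still open, it means among the compounds named here.

Measured compounds:
compound 1, `CC(/C=C/CC(C)CCCC(C)C)=C\C(=O)Oc1ccccc1`: 7.67
compound 2, `CC(/C=C/CC(C)CCCC(C)(C)OC=O)=C\C(=O)OC(C)C`: 5.4
compound 3, `C#CCSC(=O)/C=C(C)/C=C/CC(C)CCCC(C)(C)OC`: 5.9

In a physicochemical assay for lipophilicity (on this read-out higher numbers stand for higher lipophilicity and lower numbers for lower lipophilicity), compound 1 gives 7.67, the highest of the three values. The nearest number is that of compound 3, which gives 5.9, beyond the scatter below compound 1, and the furthest is compound 2 with 5.4, also beyond the scatter.

The untested compound 4, `C=CCNC(=O)/C=C(C)/C=C/CC(C)CCCC(C)C`, differs from compound 1 by allylamino in place of phenoxy on a carbonyl carbon. Within the data shown here, no measured pair shows this change, so the expectation rests on the structures alone. The change is expected to lower this assay by a step well beyond the scatter, with a number 1.77 log units lower from compound 1 to compound 4 (beyond the scatter) as the expected step. Compound 4 is thus expected to give 5.9, in the range 5.2 to 6.6.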

Compound 4, partition coefficient: 5.23
The estimate for compound 4 lay 0.67 log units above the measured number; low and high end bracket the measured number.
By their numbers in this assay, from the lowest: compounds 4 and 2 (each within the scatter of the next); then compound 3; then compound 1.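

In this assay, among these compounds, allylamino in place of phenoxy on a carbonyl carbon gives a number 2.44 log units lower from compound 1 to compound 4 (beyond the scatter), the first large step at this position read from compounds that differ in one place. The change removes an aromatic ring and adds a hydrogen-bond donor together, so this one step cannot assign its size to either. Nothing shown gives a cause for that size. Still open, as far as these compounds go, is how an anilino group, which keeps the aromatic ring and the amide hydrogen, would read in this assay. From the compounds shown here alone, an allyloxy group, which keeps the allyl chain without that hydrogen, is equally open.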